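The source may hold more compounds than are shown below. What is called first, only, known or untested is meant among the compounds shown, and "the series" means these compounds.

Measured so far: compound 1 `CCCCNC(=O)c1c(O)c2cccnc2n(-c2ccccc2)c1=O` with 12.8% in a functional assay on the whole organism for inhibition, with Rattus norvegicus as the target, read by paw edema, at a dose of 100 mg/kg by the oral route (on this read-out lower numbers stand for less inhibition and higher numbers for more inhibition at the one dose given (going by the name of the read-out)), and compound 2 `Nc1ccc(NC(=O)c2c(O)c3cccnc3n(-c3ccccc3)c2=O)cc1` with -5.5%.

Compound 2 stands lowest of the two numbers in this assay; its nearest neighbour is compound 1, and the step of a number 18.3 percentage points lower from compound 1 to compound 2 (beyond the scatter) separates them. Compound 3 `Cc1cccc(NC(=O)c2c(O)c3cccnc3n(-c3ccccc3)c2=O)c1` is not yet measured. It differs from compound 2 in one place: 3-methylphenyl in place of 4-aminophenyl on an amide-type nitrogen. Going by the values given here, the only measured step that bears on this change is the one from compound 1 to compound 2, which swapped the same position on the amide-type nitrogen and moved the read-out down by a modest amount. Among the compounds with values here, no measured pair shows a 3-methylphenyl at this position, so the comparison is indirect. For compound 3 the expected step is a number 13.5 percentage points higher from compound 2 to compound 3 (beyond the scatter), a rise back toward the region of compound 1. Compound 3 is therefore estimated at 8%, with a range from -12% to 28%.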

Compound 3, a percentage reported as inhibition, in the whole organism at one dose (the size of the read-out at that dose, not a potency): 14.2%
The estimate for compound 3 lay 6.2 percentage points below the measured number; measured number inside the range.
By their numbers in this assay, from the lowest: compound 2; then compounds 1 and 3 (each within the scatter of the next).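

In this assay, the low number of compound 2 proves not to belong to every aromatic ring on the amide-type nitrogen: 3-methylphenyl in place of 4-aminophenyl gives a number 19.7 percentage points higher from compound 2 to compound 3 (beyond the scatter). The comparison with the chain is also new, as 3-methylphenyl in place of butyl gives a number 1.4 percentage points higher from compound 1 to compound 3 (within the scatter), so this read-out does not separate these two groups at this place. No measurement available here accounts for the gap between the 4-aminophenyl and 3-methylphenyl groups.

On these data alone, the step from compound 2 to compound 3 alters both the group on the ring and its printed ring position, so the share of each remains open. A 3-aminophenyl or 4-methylphenyl group would separate the two, and a plain phenyl group would show the unsubstituted ring.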